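What a Fluoro Might Do to Compound 3

The source may hold more compounds than are shown below. What is called first, only, known or untested is meant among the compounds shown, and "the series" means these compounds.

In a functional assay on THP-1 cells (Homo sapiens) for inhibition, read by ELISA, with stated times of 2 h and 48 h (a higher number here means a weaker inhibitor, a lower number a stronger inhibitor), compound 3 (`[O-]/[N+](=C\c1cn(-c2ccccc2)nn1)Cc1ccccc1`) gives 8000 nM, and compound 1 (`[O-]/[N+](=C\c1cn(-c2ccccc2)nn1)c1ccccc1`) gives 8800 nM. These two values sit together within the scatter (a 1.1-fold lower number from compound 1 to compound 3 (0.04 log units; within the scatter)). Compound 2 (`[O-]/[N+](=C\c1cn(-c2ccc(F)cc2)nn1)c1ccccc1`) gives only a limit (> 20000 nM). Compound 4 (`[O-]/[N+](=C\c1cn(-c2ccc(F)cc2)nn1)Cc1ccccc1`) differs from compound 3 by fluoro in place of hydrogen on an aromatic carbon. Compound 2 carries that same change on compound 1, and this single measured step (an at least 2.2-fold higher number from compound 1 to compound 2 (0.35 log units; beyond the scatter)) is the one that bears on it. A similar rise, beyond the scatter, is therefore expected (a 2.3-fold higher number from compound 3 to compound 4 (0.35 log units; beyond the scatter)). Compound 4 is estimated at 18000 nM (range 9000 nM to 40000 nM), and it too may be expected to return only a limit.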

Compound 4, half-maximal inhibitory concentration: 9700 nM
Compound 4: middle estimate off by 1.9-fold (0.27 log units), on the high side, and the stated range covers the measured number.
By their numbers in this assay, from the lowest: compounds 3, 1 and 4 (each within the scatter of the next). At a limit, above all of these: compound 2.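

Fluoro in place of hydrogen does not give the same result on every core: on the core of compound 3, phenyl to 4-fluorophenyl gives a 1.2-fold higher number from compound 3 to compound 4 (0.08 log units; within the scatter). Benzyl in place of phenyl, which made no difference beyond the scatter without the fluoro, now gives an at least 2.0-fold lower number from compound 2 to compound 4 (0.31 log units; beyond the scatter). The effect of the fluoro may therefore depend on the core, but a limit stands in the way of a firm comparison: the same change on two cores in this assay, an at least 2.2-fold higher number (0.35 log units; beyond the scatter) from compound 1 to compound 2 and a 1.2-fold higher number (0.08 log units; within the scatter) from compound 3 to compound 4; the limit leaves it open whether they differ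

As far as these compounds go, whether a chloro group, a methoxy group or an amine in the same place would give a number like that of fluoro stays open. The actual number for compound 2 is also unknown, since its value is a limit.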